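Replacing a nitrile with a carboxylic acid on the chain

A few compounds are considered here, and "the series" means these few. Any claim that something is new, unique, unknown or untested is made for them only; others in the source may bear on it.

Measured compounds:
compound 1, `COc1ccc(CN(CC#N)Cc2ccc3ccccc3c2)cc1`: 0%
compound 2, `N#CCN(Cc1ccccc1)Cc1ccc2ccccc2n1`: 0%
compound 3, `N#CCCCN(Cc1ccccc1)Cc1ccc2ccccc2c1`: 0%

All three were tested in an assay on HEK293 cells for binding affinity to Substance-K receptor (Rattus norvegicus), read by FRET, tested at 10 uM; on this read-out higher numbers stand for more inhibition at the one concentration tested (going by the name of the read-out) and lower numbers for less inhibition. Compound 1 gives 0%, compound 2 gives 0%, and compound 3 gives 0%. Compound 3 thus stands level with compound 1 and compound 2 within the scatter; none of the three shows any inhibition at the digits reported.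

Compound 4, `O=C(O)CCCCN(Cc1ccccc1)Cc1ccc2ccccc2c1`, has not yet been measured in this assay . It differs from compound 3 in one place: carboxymethyl in place of cyano on a saturated chain carbon, three bonds along the chain from an amine nitrogen.

Among the compounds with values here, no step between measured compounds is available to show how such a change moves the reading in this assay . With every measured compound at the same level, nothing here points to a step in either direction, and the expected step from compound 3 to compound 4 is none beyond the scatter, so compound 4 is estimated to reach no change at the digits printed from compound 3 to compound 4 (within the scatter). The estimate for compound 4 is therefore 0%, in a range from 0% to 10%.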

Compound 4, a percentage reported as inhibition, at one concentration (the size of the read-out at that concentration, not a potency): 0%
Estimate against measurement, compound 4: no gap at the digits printed; the measured number falls inside the stated range.
By their numbers in this assay, from the lowest: compounds 1, 2, 3 and 4 (each within the scatter of the next).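

In this assay, carboxymethyl in place of cyano on a saturated chain carbon, three bonds along the chain from an amine nitrogen, gives no change at the digits printed from compound 3 to compound 4 (within the scatter). Within the data shown here, this is the first pair here that differs in one place, and it shows that with a carboxylic acid at the chain end, as with a nitrile, no inhibition appears at the digits reported. No supporting data are available to explain this result.

On these data alone, with every compound reading the same, it stays open whether this swap would matter on a compound that does show inhibition. As far as these compounds go, it is also open whether an amide or an amine at the chain end, or a longer chain, would give any reading at all.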